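Replacing chloro with ethoxy on compound 2

The source may report more compounds than this note shows. Statements on the series, on what has been measured and on what is new or still open speak of the compounds shown alone.

- compound 1 `Cc1ccc([C@@H](C)Oc2cc3onc(CCC(=O)O)c3cc2Cl)nc1` gives 99.1% 
- compound 2 `O=C(O)CCn1c(=O)oc2cc(Cl)c(Cl)cc21` gives 91.7% 
- compound 3 `Cc1ccc([C@@H](C)Oc2cc3onc(CCC(=O)O)c3cc2Cl)nn1` gives 93.3% 

All three values come from an ADME assay on the whole organism (plasma, Rattus norvegicus, strain Han-Wistar) for protein binding, read by LC-MS, at a dose of 1 mg/kg by the intravenous route, and show how much of each compound is held by plasma protein. Compound 2 lies within the usual scatter of compound 3, so the two cannot be told apart here. Compound 1 stands clearly apart from compound 2, with more bound and less free.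

The next compound to be measured is compound 4 `CCOc1cc2oc(=O)n(CCC(=O)O)c2cc1Cl`, which differs from compound 2 by one substituent. The change is ethoxy in place of chloro on an aromatic carbon and it puts ethoxy in place of chloro on an aromatic carbon, ortho to a chloro group.

Among the compounds with values here, only one measured step is available, a 7.4-fold higher unbound fraction from compound 1 to compound 3 (0.87 log units; beyond the scatter), and it lies beyond the scatter. However, it swaps a different pair of groups in a different place, so it offers only a loose guide to how far one small swap can move this read-out. Within the data shown here, no measured step covers chloro and ethoxy, so no shift beyond the scatter is expected in this assay and no direction can be favoured. The expected outcome is a 1.1-fold higher unbound fraction from compound 2 to compound 4 (0.04 log units; within the scatter) according to this estimate. For compound 4 the estimate is 91% with an expected range from 82% to 96% in this measurement.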

Compound 4, plasma protein binding in the plasma assay: 81.6%
Estimate against measurement, compound 4: 2.0-fold (0.31 log units) (unbound fraction) below; measured number outside the range, below it.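

In the plasma assay, putting ethoxy in place of chloro on this aromatic carbon, ortho to a chloro group, gives a 2.2-fold higher unbound fraction from compound 2 to compound 4 (0.35 log units; beyond the scatter), so more of the compound is free. In the plasma assay compound 2 gives 91.7% and compound 4 gives 81.6%. Within the data shown here, the earlier compounds showed a shift of this kind only for a different pair of groups in a different place, so this is the first measured sign that this position on the core of compound 2 can also move plasma protein binding. In a physicochemical assay for pharmacokinetics, at pH 6 (on this read-out lower numbers stand for a shorter-lived compound and higher numbers for a longer-lived compound), compound 2 gives 334 h. In the physicochemical assay compound 4 gives > 1000 h, which is a limit of the assay and not a number. In the physicochemical assay, the same change gives an at least 2.9-fold higher number from compound 2 to compound 4 (0.47 log units; beyond the scatter), and this step rests on a limit of the assay rather than a number, so its true size stays unknown: the limit of > 1000 h in the physicochemical assay, at which 1 of the 2 values shown sits.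

The compounds shown leave open whether the shift belongs to ethoxy alone, or whether methoxy, a longer chain such as propoxy, or an amine on the same aromatic carbon would move plasma protein binding in the same direction and as far. They also leave open whether replacing the remaining chloro group would have a similar effect on either read-out.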